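The compounds below may be only part of what the source reports. "The series", "measured", "known", "first", "only" and "open" are said of these compounds alone.

Working notes on the series

Of the compounds shown here, three have so far been measured in a functional assay (Cavia porcellus) with sulfonylurea receptors; K-ATP channels (Homo sapiens) as the target; on this read-out higher numbers stand for weaker inhibition and lower numbers for stronger inhibition. Compound 1, `CC(O)(C(=O)Nc1ccc(S(=O)(=O)c2cccc(O)c2)cc1)C(F)(F)F`, gives 18000 nM in this assay. Compound 2, `COc1cccc(S(=O)(=O)c2ccc(NC(=O)C(C)(O)C(F)(F)F)cc2)c1`, carries the change methyl in place of hydrogen on an oxygen on an aromatic ring relative to compound 1. In this assay compound 2 gives 16000 nM; that step is a 1.1-fold lower number from compound 1 to compound 2 (0.05 log units; within the scatter). Compound 3, `CC(O)(C(=O)Nc1ccc(C(=O)c2ccccc2)cc1O)C(F)(F)F`, gives 15000 nM in this assay. Compound 3 and compound 1 differ in more than one place, and the difference between the two cores is not broken down here; their values in this assay lie within the scatter of each other, as do all three measured numbers.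

Compound 4, `COc1cc(C(=O)c2ccccc2)ccc1NC(=O)C(C)(O)C(F)(F)F`, has not yet been measured. It differs from compound 3 by methyl in place of hydrogen on an oxygen on an aromatic ring. This is the same change already seen from compound 1 to compound 2, made at a place described in the same words. On the evidence of that earlier step, a 1.1-fold lower number from compound 1 to compound 2 (0.05 log units; within the scatter), the step from compound 3 to compound 4 is expected to be small, no change at the digits printed from compound 3 to compound 4 (within the scatter). Compound 4 is therefore estimated at 15000 nM in this assay, with a range from 7000 nM to 32000 nM expected.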

Compound 4, half-maximal inhibitory concentration: 6100 nM
Beside the measured number, compound 4's estimate is 2.5-fold (0.39 log units) above it; the measured number lies below the stated range.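

In this assay, the change from hydroxy to methoxy on the core of compound 3 gives a 2.5-fold lower number from compound 3 to compound 4 (0.39 log units; beyond the scatter), a modest step but one that stands clear of the scatter. Set beside the same change on the core of compound 1, this step cannot be told apart from the earlier one: the same change on two cores in this assay, a 1.1-fold lower number (0.05 log units; within the scatter) from compound 1 to compound 2 and a 2.5-fold lower number (0.39 log units; beyond the scatter) from compound 3 to compound 4, 2.2-fold (0.34 log units) apart, within the scatter of two such steps. The two cores therefore give no measured sign that the change behaves differently on one than on the other, but two steps are too few to show that it carries over unchanged, and they do not explain why only the second lies beyond the scatter.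

The compounds shown leave open whether an ethyl group or a longer chain on the same oxygen would give a step of similar size, and whether an amine in place of the methoxy would do so. From the compounds shown here alone, it also remains open how the change behaves on any core other than these two.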